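The compounds below may be only part of what the source reports. "The series", "measured", "known", "first", "only" and "open" are said of these compounds alone.

Compound 3 `C=CC(=O)Nc1cccc(NC(=O)CSc2nc(Nc3cccc(Br)c3)c3ccccc3n2)c1` gives 11900 nM in a functional assay on MGC-803 cells (Homo sapiens) for inhibition, read by MTT assay, with a stated time of 72 h; a lower number here means a stronger inhibitor, a higher number a weaker inhibitor. Compound 1 `O=C(CSc1nc(Nc2ccccc2)c2ccccc2n1)Nc1cccc(F)c1` gives 12700 nM and compound 2 `CCc1cccc(NC(=O)CSc2nc(Nc3ccccc3)c3ccccc3n2)c1` gives 15800 nM; all three numbers sit within the scatter of one another, so compound 3 stands level with the other two rather than apart from them. Compound 4 `C=CC(=O)Nc1cccc(NC(=O)CSc2nc(Nc3ccc(CC)cc3)c3ccccc3n2)c1` differs from compound 3 in one place: 4-ethylphenyl in place of 3-bromophenyl on a nitrogen on an aromatic ring. Within the data shown here, no measured pair shows this exact exchange. Among the measured compounds shown here, the only single step available, a 1.2-fold higher number from compound 1 to compound 2 (0.09 log units; within the scatter), concerns a group on an aromatic carbon rather than on the nitrogen and stays within the scatter. On that basis the step in this assay is expected to be a 1.1-fold higher number from compound 3 to compound 4 (0.02 log units; within the scatter), with no shift beyond the scatter in either direction. Compound 4 is therefore estimated at 12500 nM, with a range from 5000 nM to 32000 nM.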

Compound 4, half-maximal inhibitory concentration: 8010 nM
Compound 4: middle estimate off by 1.6-fold (0.19 log units), on the high side; measured number inside the range.
By their numbers in this assay, from the lowest: compounds 4, 3, 1 and 2 (each within the scatter of the next).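

In this assay, among these compounds, replacing 3-bromophenyl with 4-ethylphenyl on the nitrogen gives a 1.5-fold lower number from compound 3 to compound 4 (0.17 log units; within the scatter) and so gives the first direct reading at this position, which the earlier step on an aromatic carbon could not provide. For this one pair, the exchange of the aryl group leaves the two compounds level. Nothing measured here accounts for the size of the step. On these data alone, it remains open whether an amine, a carboxylic acid or a longer chain on that phenyl ring would produce a step beyond the scatter.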